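A few compounds are considered here, and "the series" means these few. Any claim that something is new, unique, unknown or untested is made for them only; others in the source may bear on it.

In an assay on isolated protein for inhibition of high affinity 3',5'-cyclic-AMP phosphodiesterase 7A (Homo sapiens), read by cAMP accumulation, with a stated time of 10 min (on this read-out higher numbers stand for weaker inhibition and lower numbers for stronger inhibition), compound 1 `COc1nc2c(c(=O)n(C)c(=O)n2C)n1CC(=O)Nc1ccc(C(C)(C)C)cc1` returns only a limit, > 200000 nM. Compound 2 `COc1nc2c(c(=O)n(C)c(=O)n2C)n1CC(=O)Nc1ccc(C(C)C)cc1` likewise returns only a limit in this assay, > 200000 nM. Going by the values given here, compound 3 `COc1nc2c(c(=O)n(C)c(=O)n2C)n1CCCC(=O)Nc1ccc(C(C)(C)C)cc1` is the one compound with a number in this assay, 19800 nM; how its core differs from the core of compound 1 is not broken down here. Compound 4 `COc1nc2c(c(=O)n(C)c(=O)n2C)n1CCCC(=O)Nc1ccc(C(C)C)cc1` has not been measured in this assay. The change from compound 3 to compound 4 is hydrogen in place of methyl on a saturated chain carbon bound to an aromatic carbon and two saturated chain carbons, the same change that separates compound 1 from compound 2, (hydrogen in place of methyl on a saturated chain carbon bound to an aromatic carbon and two saturated chain carbons). That earlier step, a step that the two limits leave unreadable from compound 1 to compound 2, cannot be sized because of the limit of > 200000 nM in this assay, at which 2 of the 3 values shown sit. The step is therefore expected to be a 1.5-fold higher number from compound 3 to compound 4 (0.18 log units; within the scatter). That expectation rests on compound 3 at 19800 nM alone, with no readable step to guide it. Compound 4 is estimated at 30000 nM, between 8000 nM and 150000 nM.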

Compound 4, half-maximal inhibitory concentration: > 200000 nM
Compound 4: a limit, no number; the forecaster's own chance of this, stated with the estimate: 25%; middle value at least 6.6-fold (0.82 log units) from the limit.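

In this assay, swapping tert-butyl for isopropyl on the core of compound 3 gives an at least 10-fold higher number from compound 3 to compound 4 (1.00 log units; beyond the scatter). Compound 4 returns only a limit, > 200000 nM, so this shows how large the step is at minimum but not its full size. The matching step on the core of compound 1 cannot be read, so nothing shows whether the change carries the same size from one core to the other, because most values here are limits: the limit of > 200000 nM in this assay, at which 3 of the 4 values shown sit.

The compounds shown leave open what a trifluoromethyl or cyclohexyl group would give in place of the tert-butyl of compound 3. They also leave open what a longer chain on the core would give.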